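Iodo in place of fluoro beside the ring nitrogen

The source may report more compounds than this note shows. Statements on the series, on what has been measured and on what is new or still open speak of the compounds shown alone.

Measured so far:
compound 1 `Clc1ncc(OC[C@@H]2CCN2)cc1/C=C/c1ccncc1` gives 0.009 nM
compound 2 `Fc1ncc(OC[C@@H]2CCN2)cc1-c1cccnc1` gives 0.066 nM
compound 3 `Brc1ncc(OC[C@@H]2CCN2)cc1-c1cccnc1` gives 0.0066 nM

All three numbers come from an assay on membranes from brain with Neuronal acetylcholine receptor; alpha4/beta2 (Rattus norvegicus) as the target; a lower number here means a stronger inhibitor, a higher number a weaker inhibitor. Among them compound 2 stands with the highest number, so it is the weakest inhibitor of the three; compound 1 sits nearest to it, and compound 3 lies furthest, both beyond the scatter. Compound 4 `Ic1ncc(OC[C@@H]2CCN2)cc1-c1cccnc1` has not yet been measured. It differs from compound 2 in one place: iodo in place of fluoro on an aromatic carbon.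

Among the compounds with values here, the one measured step that bears on this change is the one from compound 2 to compound 3, where bromo replaced fluoro at the same place and gave a 10-fold lower number from compound 2 to compound 3 (1.00 log units; beyond the scatter). Iodo in place of fluoro is a change of the same kind, so a step of comparable size in this assay, toward a lower number, is expected. Compound 4 is therefore estimated at 0.006 nM, within the range 0.0015 nM to 0.025 nM, which means an expected step of an 11-fold lower number from compound 2 to compound 4 (1.04 log units; beyond the scatter).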

Compound 4, inhibition constant: 0.0117 nM
Compound 4: the middle estimate sits 2.0-fold (0.29 log units) below what was measured; measured number inside the range.
By their numbers in this assay, from the lowest: compounds 3, 1 and 4 (each within the scatter of the next); then compound 2.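

In this assay, iodo on the aromatic carbon next to the ring nitrogen also gives a lower number than fluoro (a 5.6-fold lower number from compound 2 to compound 4 (0.75 log units; beyond the scatter)), so the drop seen with bromo is not unique to that one group. Exchanging bromo for iodo at this place gives no change that can be told from the scatter (a 1.8-fold higher number from compound 3 to compound 4 (0.25 log units; within the scatter)), so on this pair the two groups cannot be separated. No measurement shown explains why fluoro differs from the other two groups.

What the compounds shown leave open is how a methyl, a nitrile or a hydrogen at this place would compare with these halogens on the same core. Compound 1 carries a chloro there but also differs in a second place, so the chloro group's own effect cannot be read from it.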